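The source may hold more compounds than are shown below. What is called first, only, known or untested is meant among the compounds shown, and "the series" means these compounds.

In a physicochemical assay for solubility, at pH 7.4 (on this read-out lower numbers stand for lower solubility and higher numbers for higher solubility), compound 2 `O=C(NCc1ccc(-c2noc(C3CCCCC3)n2)cc1)[C@H]1NCC[C@@H]1O` reads > 50 ug/mL, which is a limit of the assay and not a number. That puts it at the limit of > 50 ug/mL in this assay, at which 1 of the 2 values shown sits. The next compound, compound 3 `CCCCCc1nc(-c2ccc(CNC(=O)[C@H]3NCC[C@@H]3O)cc2)no1`, has pentyl in place of cyclohexyl on an aromatic carbon, so an open chain replaces the ring. Among the measured compounds shown here, one measured step bears on this change. Compound 1 `CCCCCCCCc1nc(-c2ccc(CNC(=O)[C@H]3NCC[C@@H]3O)cc2)no1`, which carries octyl, gives 4 ug/mL, and cyclohexyl in place of octyl gives an at least 12-fold higher number from compound 1 to compound 2 (1.09 log units; beyond the scatter), a large step. Pentyl is also an open chain, though shorter than octyl, so in this assay part of that large step is expected to be undone, with a lower number and not as low as for compound 1. The expected change is an at least 2.5-fold lower number from compound 2 to compound 3 (0.39 log units; beyond the scatter). For compound 3 the estimate is 20 ug/mL, with an expected range from 7 ug/mL to 60 ug/mL.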

Compound 3, solubility: > 50 ug/mL
Compound 3: no number, only a limit; the forecaster's own chance of this, stated with the estimate: 25%; middle value at least 2.5-fold (0.39 log units) away from the limit.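

In this assay, an open chain on this aromatic carbon does not by itself bring back the low reading of compound 1: the shorter pentyl chain gives an at least 12-fold higher number from compound 1 to compound 3 (1.09 log units; beyond the scatter), so the cyclohexyl ring of compound 2 is not needed to leave that reading behind. Compound 3 reads > 50 ug/mL, which is a limit of the assay and not a number. The step between compound 2 and compound 3 cannot be read, because both compounds sit at this limit: the limit of > 50 ug/mL in this assay, at which 2 of the 3 values shown sit.

Going by these compounds, what stays open is the chain length between pentyl and octyl at which the reading drops, a question that a hexyl or heptyl chain on the same aromatic carbon would address. Also open, on these data alone, is how a chain ending in an amine or a carboxylic acid would read at this place.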